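A few compounds are considered here, and "the series" means these few. Any claim that something is new, unique, unknown or untested is made for them only; others in the source may bear on it.

Measured so far in a functional assay on DU-145 cells (Homo sapiens) for inhibition, read by trypan blue exclusion, with a stated time of 96 h; a lower number here means a stronger inhibitor of growth, a higher number a weaker inhibitor of growth:
compound 1, `O=C(/C(=C\c1ccc(F)c([N+](=O)[O-])c1)SCc1ccc(F)cc1)c1ccc(F)cc1`, 1000 nM
compound 2, `Cc1ccc(CS/C(=C/c2c[nH]c3ccc(Cl)cc23)C(=O)c2ccc(Cl)cc2)cc1`, 1000 nM

In this assay compound 2 stands level with compound 1 at the digits shown; the two values lie within the scatter, so no order between them is read. Compound 3 is `Cc1ccc(CS/C(=C/c2ccc(O)c(O)c2O)C(=O)c2ccc(Cl)cc2)cc1`, not yet measured. It differs from compound 2 in one place: 2,3,4-trihydroxyphenyl in place of 5-chloro-1H-indol-3-yl on a double-bonded chain carbon bound to a double-bonded chain carbon. For the measured compounds named here, no measured pair shows a step of this kind, so its size is unknown from the data. The expectation is a step of no change at the digits printed from compound 2 to compound 3 (within the scatter), not clearly beyond the scatter in either direction. On that basis compound 3 is estimated at 1000 nM, with a range from 300 nM to 3500 nM.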

Compound 3, concentration for 50% growth inhibition: 50000 nM
Beside the measured number, compound 3's estimate is 50-fold (1.70 log units) below it; the whole stated range lies below it.
By their numbers in this assay, from the lowest: compounds 1 and 2 (each within the scatter of the next); then compound 3.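

In this assay, the place on a double-bonded chain carbon bound to a double-bonded chain carbon proves sensitive to the group it carries, which compounds 1 and 2 could not show. Putting 2,3,4-trihydroxyphenyl in place of 5-chloro-1H-indol-3-yl gives a large step (a 50-fold higher number from compound 2 to compound 3 (1.70 log units; beyond the scatter)) toward weaker growth inhibition. No available evidence bears on the reason for this step.

This single change does not separate the effect of the three hydroxyl groups from that of removing 5-chloro-1H-indol-3-yl. Going by these compounds, how an unsubstituted phenyl or a methoxyphenyl would stand at this place remains open.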